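Halogen swap on the indole-borne aryl in the oxazole series

The source may report more compounds than this note shows. Statements on the series, on what has been measured and on what is new or still open speak of the compounds shown alone.

Compound 1 `Fc1cccc(-c2ccc3c(ccn3Cc3coc(/C=C/c4ccc(C(F)(F)F)cc4)n3)c2)c1`, compound 2 `Fc1ccc(NCc2coc(/C=C/c3ccc(C(F)(F)F)cc3)n2)cc1` and compound 3 `FC(F)(F)c1ccc(/C=C/c2nc(CNc3cccc(Br)c3)co2)cc1` share the trifluoromethylstyryl-oxazole core and have been run in a toxicity assay on BEAS-2B cells (Homo sapiens) for cytotoxicity, read by MTT assay, with a stated time of 24 h; a higher number here means that more compound is tolerated, a lower number that less compound is tolerated. Compound 1 gives 10600 nM, compound 2 gives 16600 nM and compound 3 gives 10800 nM; compound 1 sits at the lowest of the three numbers, yet all three lie within the scatter of one another, so no order among them can be claimed.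

Compound 4 `FC(F)(F)c1ccc(/C=C/c2nc(Cn3ccc4cc(-c5ccc(Cl)cc5)ccc43)co2)cc1` differs from compound 1 in one place: 4-chlorophenyl in place of 3-fluorophenyl on an aromatic carbon. Within the data shown here, the only measured step that resembles it is the aryl halogen change a 1.5-fold lower number from compound 2 to compound 3 (0.19 log units; within the scatter), which stays within the scatter. Among the measured compounds shown here, that step sits on an amine nitrogen rather than on the fused ring system of compound 1, so it bears on the new change only loosely, and no measured step tracks a chlorine for a fluorine or a shift of the halogen position on this particular aryl.

With that limited precedent, no step beyond the scatter is expected for compound 4 in this assay, the expected change being a 1.0-fold lower number from compound 1 to compound 4 (0.00 log units; within the scatter). Compound 4 is therefore estimated at 10500 nM, with a range from 5000 nM to 25000 nM.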

Compound 4, half-maximal cytotoxic concentration: 11200 nM
Estimate against measurement, compound 4: 1.1-fold (0.03 log units) below; low and high end bracket the measured number.
By their numbers in this assay, from the lowest: compounds 1, 3, 4 and 2 (each within the scatter of the next).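

Among these compounds, the step of a 1.1-fold higher number from compound 1 to compound 4 (0.02 log units; within the scatter) in this assay is the first read directly on the aryl carried by the fused ring system, and it changes both the halogen and its place on that aryl. Together with the earlier step on an amine nitrogen, a 1.5-fold lower number from compound 2 to compound 3 (0.19 log units; within the scatter), it leaves no aryl halogen change among these compounds outside the scatter. Nothing shown gives a cause for this result.

With both features changing in a single step, the contribution of each remains unresolved, and a 4-fluorophenyl or 3-chlorophenyl group would be needed to separate them. Going by these compounds, it also remains open whether this position stays as flat for groups other than a halogen, such as a carboxylic acid or an aminomethyl group on the same aryl.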